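The compounds below may be only part of what the source reports. "The series", "measured", "known", "first", "only" and "open" are said of these compounds alone.

Working notes on the series. Compound 1 `COc1ccc(-c2cc(=O)c3c(OC)cc(OC)cc3n2S(=O)(=O)c2cc(Cl)cc(Cl)c2O)cc1` gives in a functional assay on SEM cells (Homo sapiens) for antiproliferative activity, with a stated time of 72 h; a lower number here means that less compound is needed, a higher number that more compound is needed for the effect "not determined" (no result reported), that is, no result. Compound 2 `COC(=O)c1cc(=O)c2cc(NC(=O)Nc3ccc(Cl)c(C(F)(F)F)c3)ccc2[nH]1` gives in this assay only a limit, > 6350 nM. Compound 3 `COC(=O)c1cc(=O)c2cc(NC(=O)Nc3ccc(Cl)c(Cl)c3)ccc2[nH]1` likewise gives in this assay only a limit, > 6350 nM. Among the measured compounds shown here, the single measured step, a step that the two limits leave unreadable from compound 2 to compound 3, therefore stays unreadable. Across the three entries, compound 3 stands on a limit, one further value is a limit as well, and one further entry carries no number at all; the evidence on this point is the limit of > 6350 nM in this assay, at which 2 of the 3 values shown sit.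

The step of interest leads to compound 4 `COC(=O)c1cc(=O)c2cc(NC(=O)Nc3cccc(C(C)=O)c3)ccc2[nH]1`. Relative to compound 3, the change is 3-acetylphenyl in place of 3,4-dichlorophenyl on an amide-type nitrogen. For the measured compounds named here, the only measured step in this assay does not bear on it in a readable way, since both of its endpoints are limits, so nothing measured here tells whether exchanging the 3,4-dichlorophenyl for the 3-acetylphenyl moves the value in either direction beyond the scatter.

With two of three entries sitting at the same limit, the expected outcome for compound 4 is an estimate near that limit, 9000 nM, within 2000 nM to 40000 nM. The step this estimate means is expected to be a step that the limit leaves unreadable from compound 3 to compound 4.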

Compound 4, half-maximal effective concentration: > 8080 nM
Compound 4 ended at the assay's limit; the forecaster's own chance of this, stated with the estimate: 65%; the middle value does not contradict the limit.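

In this assay compound 4 gives only a limit, > 8080 nM. Compound 3 likewise gives only a limit, > 6350 nM, so the step between these two compounds cannot be read. The compounds shown leave open whether any group exchanged on the amide-type nitrogen moves the value in this assay at all, with compound 2, compound 3 and compound 4 all standing on limits.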